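This account rests on a few compounds, and the source may have more. Where it says the series, first, only, none or still open, it means among the compounds named here.

Measured compounds:
compound 1, `CN1CCN(Cc2ccc(NC(=O)Nc3ccc4ncnc(Nc5ccc(F)c(Cl)c5)c4c3)cc2)CC1` — 3480 nM
compound 2, `O=C(Nc1ccc(CN2CCCCC2)cc1)Nc1ccc2ncnc(Nc3cccc(C(F)(F)F)c3)c2c1` — 1050 nM
compound 3, `CN(C)Cc1ccc(NC(=O)Nc2ccc3ncnc(Nc4cccc(C(F)(F)F)c4)c3c2)cc1` — 1120 nM

Of the compounds shown here, three sharing one core have been measured in a functional assay on A549 cells (Homo sapiens) for antiproliferative activity, read by MTT assay, with a stated time of 72 h; a lower number here means a stronger inhibitor, a higher number a weaker inhibitor. Compound 1 gives 3480 nM, the highest of the three numbers; compound 2 gives 1050 nM and compound 3 gives 1120 nM, both beyond the scatter below compound 1. Within the data shown here, the only measured step that changes one place is a 1.1-fold higher number from compound 2 to compound 3 (0.03 log units; within the scatter), which concerns the amine on the benzylic carbon and leaves the two values within the scatter of each other.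

The unmeasured compound 4, `C[C@@H](Nc1ncnc2ccc(NC(=O)Nc3ccc(CN4CCN(C)CC4)cc3)cc12)c1ccccc1`, differs from compound 1 at a different place: 1-phenylethyl in place of 3-chloro-4-fluorophenyl on a nitrogen on an aromatic ring. Among the measured compounds shown here, no measured step touches this nitrogen, so nothing among the three compounds tells how large a change here would be or in which direction. The step from compound 2 to compound 3 bears on another part of the molecule and gives no guidance. Compound 1 is the only point of reference, and it stands highest among the numbers shown.

For the measured compounds named here, with no step to lean on, compound 4 is expected to stay near compound 1, with a 1.4-fold lower number from compound 1 to compound 4 (0.14 log units; within the scatter) as the estimated step and a wide uncertainty. Compound 4 is therefore estimated at 2500 nM, within a range of 600 nM to 10000 nM.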

Compound 4, half-maximal inhibitory concentration: > 10000 nM
Compound 4 was reported as a limit (the forecaster's own chance of this, stated with the estimate: 10%); at least 4.0-fold (0.60 log units) between middle value and limit.
By their numbers in this assay, from the lowest: compounds 2 and 3 (each within the scatter of the next); then compound 1. At a limit, above all of these: compound 4.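

In this assay, among these compounds, the nitrogen on an aromatic ring proves sensitive to what it carries: replacing the (3-chloro-4-fluorophenyl)amino group with (1-phenylethyl)amino gives an at least 2.8-fold higher number from compound 1 to compound 4 (0.45 log units; beyond the scatter), whereas the only earlier step, at the amine on the other side of the molecule, stayed within the scatter. Compound 4 stands at a limit of the assay, > 10000 nM, so the step gives only a minimum size: the limit of > 10000 nM in this assay, at which 1 of the 4 values shown sits. Both groups hold 8 heavy atoms and one six-membered aromatic ring of carbon only, so neither count separates them, and the higher number comes with a change that loses chlorine and fluorine and adds a defined stereocentre together.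

On these data alone, what remains open is which of these differences matters, and a plain phenylamino group, a benzylamino group and the opposite enantiomer of 1-phenylethyl on this nitrogen would begin to separate them. As far as these compounds go, it also remains open whether the same change would behave alike with piperidin-1-yl or dimethylamino on the benzylic carbon in place of the methylpiperazine of compound 1.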